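Ring-Opened Amide in a Sulfonylpiperazine Series

The compounds below may be only part of what the source reports. "The series", "measured", "known", "first", "only" and "open" are said of these compounds alone.

compound 1: `CC(C(=O)N1CCC2(CC1)CC2)N1CCN(S(=O)(=O)c2ccc(C(C)(C)C)cc2)CC1` — > 40000 nM
compound 2: `CC(C(=O)N1Cc2ccccc2C1)N1CCN(S(=O)(=O)c2ccc(C(C)(C)C)cc2)CC1` — > 40000 nM

Of the compounds shown here, two have so far been measured in an ADME assay on HepG2 cells (Homo sapiens) for inhibition, with a stated time of 48 h; a lower number here means that less compound is needed, a higher number that more compound is needed for the effect. Compound 1, `CC(C(=O)N1CCC2(CC1)CC2)N1CCN(S(=O)(=O)c2ccc(C(C)(C)C)cc2)CC1`, gives > 40000 nM, which is a limit of the assay and not a number. Compound 2, `CC(C(=O)N1Cc2ccccc2C1)N1CCN(S(=O)(=O)c2ccc(C(C)(C)C)cc2)CC1`, gives > 40000 nM, again a limit. The step that the two limits leave unreadable from compound 1 to compound 2 is therefore unreadable; both values sit at the limit of > 40000 nM in this assay, at which 2 of the 2 values shown sit. Compound 2 thus stands only at that limit, with no number placing it more closely.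

Compound 3, `CC(C(=O)N(C)Cc1ccccc1)N1CCN(S(=O)(=O)c2ccc(C(C)(C)C)cc2)CC1`, differs from compound 2 by a group of 9 heavy atoms (8 carbon, 1 nitrogen; one six-membered aromatic ring of carbon only) in place of a group of 9 heavy atoms (8 carbon, 1 nitrogen; one five-membered non-aromatic ring with 1 hetero atom, one six-membered aromatic ring of carbon only), on a carbonyl carbon. Among the measured compounds shown here, the single measured step touches the same carbonyl carbon but yields no readable size, so neither direction nor magnitude can be taken from it. With both measured compounds at the limit, compound 3 is expected to sit at or past the limit too, a step that the limit leaves unreadable from compound 2 to compound 3 of no readable size. Compound 3 is estimated at 60000 nM, within a range from 20000 nM to 200000 nM.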

Compound 3, half-maximal effective concentration: > 40000 nM
Compound 3: a limit, no number; the forecaster's own chance of this, stated with the estimate: 85%; the middle value lies beyond the limit too.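

In this assay compound 3 gives > 40000 nM, which is a limit and not a number. Among the compounds shown here, no step among compound 1, compound 2 and compound 3 can therefore be read: the limit of > 40000 nM in this assay, at which 3 of the 3 values shown sit. The compounds shown leave open whether any group on the carbonyl carbon changes the concentration needed for the effect.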